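The source may hold more compounds than are shown below. What is called first, only, known or untested is meant among the compounds shown, and "the series" means these compounds.

Measured in an ADME assay on L6 cells (Rattus norvegicus) for cytotoxicity, read by resazurin assay, with a stated time of 72 h; on this read-out lower numbers stand for stronger inhibition and higher numbers for weaker inhibition:
- compound 1 `OC(c1ccc(Cl)cc1)(c1ccc(Br)cc1)c1cccnc1`: 57000 nM
- compound 2 `OC(c1ccc(Cl)cc1)(c1ccc(C(F)(F)F)cc1)c1cccnc1`: 56400 nM
- compound 3 `COc1ccc(C(O)(c2ccc(Cl)cc2)c2cccnc2)cc1`: 68100 nM

Compound 1, at 57000 nM, stands level with the other two, as all three values lie within the scatter of one another. The next compound to be measured is compound 4 `OC(c1ccc(Cl)cc1)(c1cccnc1)c1cccc(Br)c1`. It has the same atoms as compound 1, joined differently: 3-bromophenyl in place of 4-bromophenyl on a saturated chain carbon bound to two aromatic carbons and an oxygen on a saturated carbon.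

The closest evidence comes from replacing the bromo group. The results were a 1.0-fold lower number from compound 1 to compound 2 (0.00 log units; within the scatter) and a 1.2-fold higher number from compound 1 to compound 3 (0.08 log units; within the scatter), and the remaining pair gave a 1.2-fold higher number from compound 2 to compound 3 (0.08 log units; within the scatter). All of these are small and within the scatter. However, these steps exchange one group for another, and no measured pair shows the same group moved to a different position, so the evidence is only indirect. Even so, no shift beyond the scatter is expected in this assay, in either direction. The expected result is no change at the digits printed from compound 1 to compound 4 (within the scatter), which would remain within the scatter. For compound 4 the estimated value is 57000 nM, with an expected range from 30000 nM to 100000 nM.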

Compound 4, half-maximal inhibitory concentration: 54100 nM
The estimate for compound 4 lay 1.1-fold (0.02 log units) above the measured number; low and high end bracket the measured number.
By their numbers in this assay, from the lowest: compounds 4, 2, 1 and 3 (each within the scatter of the next).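

Moving the bromine gives the first look at a change of position rather than a change of group: in this assay, 3-bromophenyl in place of 4-bromophenyl gives a 1.1-fold lower number from compound 1 to compound 4 (0.02 log units; within the scatter). For this pair, then, where the bromine sits on the ring makes no difference that can be told from the scatter, just as exchanging bromo for trifluoromethyl or methoxy made none. Nothing measured here bears on the reason for this result.

From the compounds shown here alone, all four compounds keep the rest of the core of compound 1, so it remains open whether an amine or a carboxylic acid in place of the bromo group would shift the number. Going by these compounds, it is also open whether moving trifluoromethyl or methoxy in the same way would leave the number just as level.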